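This account rests on a few compounds, and the source may have more. Where it says the series, first, only, none or still open, it means among the compounds named here.

The measured compounds so far:
Compound 1 `CCNS(=O)(=O)c1ccc(NC2CC2)c(NCc2ccncc2)c1` gives 128 nM in a functional assay (IMR-32 cells, Homo sapiens) for inhibition, read by fluorescence, with stated times of 1 h and 13 h; on this read-out higher numbers stand for weaker inhibition and lower numbers for stronger inhibition.
Compound 2 `CCNS(=O)(=O)c1ccc(NC2CC3CCC2C3)c(NCc2ccncc2)c1` gives 9.4 nM in this assay.

Only these two compounds have been measured in this assay. Going by the values given here, compound 2 has the lower of the two numbers, and its nearest neighbour is compound 1; the single step on record, a 14-fold lower number from compound 1 to compound 2 (1.13 log units; beyond the scatter), separates them and is well beyond the scatter.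

Compound 3 `CCNS(=O)(=O)c1ccc(NC2CCCCCCC2)c(NCc2ccncc2)c1` has not yet been measured. It differs from compound 2 in one place: a group of 8 heavy atoms (8 carbon; one eight-membered non-aromatic ring of carbon only) in place of a group of 7 heavy atoms (7 carbon; 2 five-membered non-aromatic rings of carbon only), on a nitrogen on an aromatic ring. Among the compounds with values here, the one measured step, a 14-fold lower number from compound 1 to compound 2 (1.13 log units; beyond the scatter), concerns the same nitrogen on the aromatic ring and shows that moving from a three-membered ring to two fused five-membered rings there went with a large drop in the number. Within the data shown here, the change to compound 3 swaps one all-carbon non-aromatic ring system for another of comparable atom count, so no step of that kind is expected; the step of a 1.6-fold higher number from compound 2 to compound 3 (0.20 log units; within the scatter) is estimated to stay within the scatter, with at most a modest rise in the number. Compound 3 is therefore expected to give about 15 nM, within a range from 4 nM to 60 nM.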

Compound 3, half-maximal inhibitory concentration: 22 nM
The estimate for compound 3 lay 1.5-fold (0.17 log units) below the measured number; the range from low to high includes it.
By their numbers in this assay, from the lowest: compound 2; then compound 3; then compound 1.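

In this assay, the step of a 5.8-fold lower number from compound 1 to compound 3 (0.76 log units; beyond the scatter) shows that a single large ring, cyclooctyl, on this nitrogen on an aromatic ring also goes with a clearly lower number than cyclopropyl, so two five-membered rings are not required for such a fall. The two larger groups are still not interchangeable: the step of a 2.3-fold higher number from compound 2 to compound 3 (0.37 log units; beyond the scatter) shows that compound 3 has the higher number even though its group holds more carbon atoms, so compound 3 goes against any simple rule that more carbon on this nitrogen gives a lower number. Nothing available explains either step.

The compounds shown leave open how cyclopentyl or cyclohexyl would compare on this nitrogen, so it cannot be said whether the number falls steadily as a single ring grows or stops falling at a smaller size. Also open, from the compounds shown here alone, is whether a ring is needed at all, which an open chain such as n-hexyl would test, and whether a ring containing oxygen, such as tetrahydropyranyl, would keep the number low.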